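This account rests on a few compounds, and the source may have more. Where it says the series, first, only, none or still open, it means among the compounds named here.

For the measured compounds named here, compound 1 `Cc1nc(S(C)(=O)=O)ccc1Oc1ncnc(OC2CCN(C(=O)OC3CCC3)CC2)c1F` stands lowest of the three numbers so far obtained in a functional assay on isolated protein for inhibition of Glucose-dependent insulinotropic receptor (Rattus norvegicus), read by HTRF and cAMP accumulation; a higher number here means that more compound is needed for the effect, a lower number that less compound is needed: compound 1 gives 167 nM. Compound 2 `Cc1nc(S(C)(=O)=O)ccc1Oc1ncnc(OC2CCN(C(=O)O[C@H](C)CF)CC2)c1F` gives 1520 nM, and compound 3 `Cc1nc(S(C)(=O)=O)ccc1Oc1ncnc(OC2CCN(C(=O)OC3COC3)CC2)c1F` gives 2500 nM. Both of these replace the cyclobutyl on the oxygen next to the carbonyl group and both move away from compound 1: a 9.1-fold higher number from compound 1 to compound 2 (0.96 log units; beyond the scatter), and a 15-fold higher number from compound 1 to compound 3 (1.18 log units; beyond the scatter). Compound 4 `CCC(F)(F)C(=O)N1CCC(Oc2ncnc(Oc3ccc(S(C)(=O)=O)nc3C)c2F)CC1` differs from compound 1 in another way, namely (1,1-difluoropropyl in place of cyclobutyloxy on a carbonyl carbon). Here the whole cyclobutyloxy is exchanged for a chain, not merely the ring on it, so no measured step matches the change directly. What the two measured steps do show is that every departure from the cyclobutyl of compound 1 has so far given a higher number, once modest and once large, and a change of similar or greater extent is taken to point the same way. Compound 4 is therefore expected to give 900 nM, within a range from 200 nM to 4000 nM. The step this estimate implies is a 5.4-fold higher number from compound 1 to compound 4 (0.73 log units; beyond the scatter), a rise expected to lie beyond the scatter but with wide uncertainty.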

Compound 4, half-maximal effective concentration: 69.2 nM
Compound 4: the middle estimate sits 13-fold (1.11 log units) above what was measured, outside the stated range (below it).
By their numbers in this assay, from the lowest: compound 4; then compound 1; then compounds 2 and 3 (each within the scatter of the next).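

In this assay, the place on the carbonyl carbon proves able to move the number down as well as up: 1,1-difluoropropyl in place of cyclobutyloxy gives a 2.4-fold lower number from compound 1 to compound 4 (0.38 log units; beyond the scatter) and so breaks the earlier run in which every departure from compound 1 gave a higher number. The gaps to the other two groups are wider, with a 36-fold lower number from compound 3 to compound 4 (1.56 log units; beyond the scatter) and a 22-fold lower number from compound 2 to compound 4 (1.34 log units; beyond the scatter) showing how much this one place matters while the rest of the structure stays fixed. Nothing available here explains these differences.

The compounds shown leave open whether the lower number goes with the two fluorines, with the chain, or with the loss of the oxygen on the carbonyl carbon. A plain propyl chain or a cyclobutyl set directly on the carbonyl carbon would begin to separate these.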